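Methylamino to acetamido on a shared core

A few compounds are considered here, and "the series" means these few. Any claim that something is new, unique, unknown or untested is made for them only; others in the source may bear on it.

Compound 1 (`CCC1=C(C(=O)OCC2CCCCC2)C(c2ccc(N)cc2)NC(=O)N1`) and compound 2 (`CCC1=C(C(=O)OCC2CCCCC2)C(c2ccc(NC)cc2)NC(=O)N1`) share one core and differ only on a nitrogen on an aromatic ring. In an ADME assay on CEMx174 cells (Homo sapiens) for cytotoxicity (on this read-out lower numbers stand for higher toxicity in this test and higher numbers for lower toxicity in this test), compound 1 gives > 10000 nM, which is a limit of the assay and not a number. Compound 2 gives > 10000 nM, which is likewise a limit, so it has no exact value. Within the data shown here, the one measured step is a step that the two limits leave unreadable from compound 1 to compound 2, and it offers no size to carry forward. The remaining evidence is the limit of > 10000 nM in this assay, at which 2 of the 2 values shown sit. Compound 3 (`CCC1=C(C(=O)OCC2CCCCC2)C(c2ccc(NC(C)=O)cc2)NC(=O)N1`) carries acetyl in place of methyl on that nitrogen: acetyl in place of methyl on a nitrogen on an aromatic ring. On this evidence, no clear change is expected in this assay, and the expected step is a step that the limit leaves unreadable from compound 2 to compound 3. The estimate for compound 3 is 20000 nM, with an expected range from 8000 nM to 50000 nM.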

Compound 3, half-maximal cytotoxic concentration: > 10000 nM
Compound 3: no number, only a limit; the forecaster's own chance of this, stated with the estimate: 85%; the middle value is on the limit's open side.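

In this assay compound 3 gives > 10000 nM, which is a limit of the assay and not a number. Among these compounds, no step from compound 1 or compound 2 to compound 3 can be read. The compounds shown leave open whether hydrogen, methyl or acetyl on that nitrogen makes any difference in this assay.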